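A few compounds are considered here, and "the series" means these few. Any claim that something is new, unique, unknown or untested is made for them only; others in the source may bear on it.

Compound 1 `OC[C@H]1C[C@@H](Cn2cnc3c(-c4ccc(Cl)cc4)ncnc32)c2ccccc21` is the reference point of this set. Within the data shown here, in a functional assay on MOLT-4 cells (Homo sapiens) (a higher number here means a weaker inhibitor, a lower number a stronger inhibitor), compound 1 gives 0.63 ug/mL, the lowest number among the three compounds measured so far. Compound 2 `Cn1ncc2c1[C@H](Cn1cnc3c(Cl)nc(N)nc31)C[C@@H]2CO` gives 3.2 ug/mL, and compound 3 `OC[C@H]1C[C@@H](Cn2cnc3c(NC4CC4)ncnc32)c2ccccc21` gives 24 ug/mL. Among the measured compounds shown here, the only single-point comparison available is between compound 1 and compound 3, where swapping the whole 4-chlorophenyl group for cyclopropylamino produced a 38-fold higher number from compound 1 to compound 3 (1.58 log units; beyond the scatter), a large loss of potency.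

Compound 4 `Cc1ccc(-c2ncnc3c2ncn3C[C@@H]2C[C@H](CO)c3ccccc32)cc1` differs from compound 1 in a much smaller way: methyl in place of chloro on an aromatic carbon. Seen one bond further out, 4-chlorophenyl becomes 4-methylphenyl, so the aromatic group that was lost entirely in compound 3 is kept here, with only its outer substituent exchanged. For the measured compounds named here, no measured step in this set isolates that exchange. The step from compound 1 to compound 3 shows that the 4-chlorophenyl group as a whole is important, but it says nothing about chloro against methyl. With no direct evidence, the expectation is a step no larger than the usual scatter, in either direction. Compound 4 is therefore expected to give about 0.8 ug/mL, within a range from 0.3 ug/mL to 2 ug/mL, which corresponds to an estimated step of a 1.3-fold higher number from compound 1 to compound 4 (0.10 log units; within the scatter).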

Compound 4, half-maximal inhibitory concentration: 1.4 ug/mL
The estimate for compound 4 lay 1.8-fold (0.24 log units) below the measured number; the range from low to high includes it.
By their numbers in this assay, from the lowest: compound 1; then compound 4; then compound 2; then compound 3.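

In this assay, the step of a 2.2-fold higher number from compound 1 to compound 4 (0.35 log units; beyond the scatter) shows that the outer substituent on this aromatic ring matters: chloro and methyl each count a single heavy atom and neither carries a hydrogen-bond donor or acceptor, yet the exchange moves the number modestly beyond the scatter. The step of a 17-fold lower number from compound 3 to compound 4 (1.23 log units; beyond the scatter) shows that the large gap to cyclopropylamino is not peculiar to the 4-chlorophenyl group, since a 4-methylphenyl group also gives a much lower number than cyclopropylamino does on the same aromatic carbon. Taken together, these steps show that in these three compounds, having either of these two substituted phenyl groups rather than cyclopropylamino accounts for a far larger change than the choice between chloro and methyl.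

On these data alone, whether any other outer group, such as fluoro, methoxy, an amine or a carboxylic acid, would match or improve on chloro remains open. So does whether an unsubstituted phenyl group would sit closer to the 4-chlorophenyl or the 4-methylphenyl compound. Nothing presented here offers a reason for the difference between chloro and methyl.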